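This account rests on a few compounds, and the source may have more. Where it says the series, first, only, none or still open, it means among the compounds named here.

Measured in an ADME assay on K562 cells (Homo sapiens) for antiproliferative activity; on this read-out lower numbers stand for stronger inhibition and higher numbers for weaker inhibition:
- compound 1 `COc1ccc2nccc(CC[C@H]3CC[C@H](NCc4ccc(Cl)c(Cl)c4)CC3)c2c1`: "not determined" (no result reported)
- compound 2 `COc1ccc2nccc(CC[C@H]3OC[C@H](NCc4ccc5c(n4)NC(=O)CS5)CO3)c2c1`: 31000 nM
- compound 3 `COc1ccc2nccc(CC[C@H]3OC[C@H](NCc4ccc(Cl)cc4)CO3)c2c1`: 12000 nM

Compound 1 has no single number in this assay, so it gives no starting point. Compound 4 `COc1ccc2nccc(CC[C@H]3CC[C@H](NCc4cc5c(cn4)OCCO5)CC3)c2c1` differs from it by a group of 10 heavy atoms (7 carbon, 1 nitrogen, 2 oxygen; one six-membered non-aromatic ring with 2 hetero atoms, one six-membered aromatic ring with 1 hetero atom) in place of a group of 8 heavy atoms (6 carbon, 2 chlorine; one six-membered aromatic ring of carbon only), on a saturated chain carbon bound to an amine nitrogen. Within the data shown here, one measured step bears on this, though on a different core: a 2.6-fold lower number from compound 2 to compound 3 (0.41 log units; beyond the scatter). The group that leaves in that step has the same ring description as the group entering compound 4. Compound 2, which carries that group, reads 31000 nM, so a modest step towards a higher number is expected for the change from compound 1, though its size cannot be anchored. Compound 4 is estimated at 25000 nM, with an expected range of 8000 nM to 80000 nM.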

Compound 4, half-maximal inhibitory concentration: 7500 nM
Estimate against measurement, compound 4: 3.3-fold (0.52 log units) above; measured number outside the range, below it.
By their numbers in this assay, from the lowest: compounds 4 and 3 (each within the scatter of the next); then compound 2.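

In this assay compound 1 has no number, so its change to compound 4 cannot be read as a step. On these data alone, what replacing the 3,4-dichlorophenyl group does on this core stays open, and no measured evidence bears on the result of compound 4.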